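Swapping the Sulfonyl Aryl Group: Three Limits, One Estimate

The compounds below may be only part of what the source reports. "The series", "measured", "known", "first", "only" and "open" are said of these compounds alone.

Three sulfonamides built on one shared core have been tested in an assay on isolated protein for inhibition of malate dehydrogenase, mitochondrial (Sus scrofa), with stated times of 45 min and 30 min; on this read-out higher numbers stand for weaker inhibition and lower numbers for stronger inhibition. Compound 1 `O=S(=O)(Nc1ccc2oc(-c3ccccc3)nc2c1)c1ccc(Cl)c(Cl)c1` carries a 3,4-dichlorophenyl group on the sulfonyl sulfur; in this assay compound 1 gives only > 63000 nM, which is a limit of the assay and not a number. Compound 2 `O=S(=O)(Nc1ccc2oc(-c3ccccc3)nc2c1)c1cccc(C(F)(F)F)c1` places a trifluoromethyl-bearing ring on the same sulfur; in this assay compound 2 likewise gives only the limit > 63000 nM. Compound 3 `O=S(=O)(Nc1ccc2oc(-c3ccccc3)nc2c1)c1ccccc1Cl`, with 2-chlorophenyl on the sulfonyl sulfur, also stops at the limit > 63000 nM in this assay. Compound 3 therefore stands exactly where the other two stand, at a limit with no number beneath it, and a step that the two limits leave unreadable from compound 1 to compound 3 cannot be read.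

Compound 4 `Cc1cccc(S(=O)(=O)Nc2ccc3oc(-c4ccccc4)nc3c2)c1` differs from compound 3 in a single place: 3-methylphenyl in place of 2-chlorophenyl on a sulfonyl sulfur. For the measured compounds named here, the only measured step that touches this position is a step that the two limits leave unreadable from compound 1 to compound 3, and it is unreadable because all three values sit at the limit of > 63000 nM in this assay, at which 3 of the 3 values shown sit. Going by the values given here, no measured step therefore suggests any direction for this change. Compound 4 is expected to remain at the limit as well, so the estimated step that the limit leaves unreadable from compound 3 to compound 4 is none beyond the scatter. Compound 4 is accordingly estimated at 100000 nM in this assay, between 40000 nM and 300000 nM, most probably reported again only as a limit.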

Compound 4, half-maximal inhibitory concentration: > 63000 nM
Compound 4: only a limit was reported; the forecaster's own chance of this, stated with the estimate: 80%; the middle value is on the limit's open side.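

In this assay compound 4 gives only > 63000 nM as a limit of the assay and not a number. For the compounds shown here, no step between compound 4 and compound 1, compound 2 or compound 3 can be read, because all four stop at the same limit: the limit of > 63000 nM in this assay, at which 4 of the 4 values shown sit. The compounds shown leave open whether any of these four groups on the sulfonyl sulfur differs from another in inhibition.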